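Swapping Chloro for Fluoro on a Shared Core

A few compounds are considered here, and "the series" means these few. Any claim that something is new, unique, unknown or untested is made for them only; others in the source may bear on it.

Compound 3 `O=C1CSC(c2c[nH]nc2-c2ccc(Cl)cc2)N1n1c(S)nnc1COc1ccc2ccccc2c1` has the higher of the two numbers that were obtained in a functional assay on MCF7 cells (Homo sapiens) for inhibition, read by MTT assay, with a stated time of 24 h; a higher number here means a weaker inhibitor, a lower number a stronger inhibitor: in that assay compound 3 gives 100 ug/mL. Its nearest neighbour is compound 1 `O=C1CSC(c2c[nH]nc2-c2ccc(F)cc2)N1n1c(S)nnc1COc1ccccc1`, which in this assay gives 30 ug/mL. Compound 2 `Cc1ccc(OCc2nnc(S)n2N2C(=O)CSC2c2c[nH]nc2-c2ccc(F)cc2)cc1` gives in this assay only a limit of the assay, > 100 ug/mL; one of the three results sits at the limit of > 100 ug/mL in this assay, at which 1 of the 3 values shown sits.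

Among the measured compounds shown here, the single measured step that changes one place runs an at least 3.3-fold higher number from compound 1 to compound 2 (0.52 log units; beyond the scatter), and that change sits on the phenoxy part of the shared core, not on the halogen. Compound 4 `O=C1CSC(c2c[nH]nc2-c2ccc(F)cc2)N1n1c(S)nnc1COc1ccc2ccccc2c1` is compound 3 with fluoro in place of chloro on an aromatic carbon. For the measured compounds named here, compound 1 and compound 3 differ in two places at once, so their two values cannot isolate this swap, and no measured step bears on it directly. Without such a guide, no movement beyond the scatter is expected, and the expected step is a 1.3-fold lower number from compound 3 to compound 4 (0.10 log units; within the scatter). Compound 4 is therefore estimated at 80 ug/mL in this assay, with a range from 30 ug/mL to 200 ug/mL.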

Compound 4, half-maximal inhibitory concentration: > 100 ug/mL
Compound 4: only a limit was reported; the forecaster's own chance of this, stated with the estimate: 30%; at least 1.2-fold (0.09 log units) between middle value and limit.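

Putting fluoro in place of chloro on this aromatic carbon gives a number no lower from compound 3 to compound 4 (the limit leaves the size open) in this assay, so the swap brings no gain in inhibition when naphthalen-2-yl is present. With fluoro held fixed, placing naphthalen-2-yl in place of phenyl on the oxygen gives an at least 3.3-fold higher number from compound 1 to compound 4 (0.52 log units; beyond the scatter), so this larger change on the other side of the shared core clearly weakens inhibition. Compound 4 has only a limit of the assay, as does compound 2, so the step between them cannot be read: the limit of > 100 ug/mL in this assay, at which 2 of the 4 values shown sit.

Going by these compounds, whether compound 4 truly differs from compound 3 remains open, and so does whether the halogen swap would matter with phenyl on the oxygen, where inhibition can still be read. Also open, on these data alone, is what an amine, a hydroxyl or a nitrile on this same aromatic carbon would do.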